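The compounds below may be only part of what the source reports. "The series", "measured", "known", "first", "only" and "open" are said of these compounds alone.

Compound 3 `COC(=O)c1c(C)cccc1OC(=O)COc1cc(O)c2c(=O)cc(-c3ccccc3)oc2c1` gives 37200 nM in a functional assay on cells (T-cell, Mus musculus, strain BALB/c) for inhibition, read by MTT assay, with a stated time of 72 h (a higher number here means a weaker inhibitor, a lower number a stronger inhibitor), the highest of the three numbers shown; compound 1 `COC(=O)c1ccc(C)cc1OC(=O)COc1cc(O)c2c(=O)cc(-c3ccccc3)oc2c1` gives 31100 nM and the two sit within the scatter of each other, as a 1.2-fold higher number from compound 1 to compound 3 (0.08 log units; within the scatter) shows. Compound 2 `COC(=O)c1ccc(Cl)cc1OC(=O)COc1cc(O)c2c(=O)cc(-c3ccccc3)oc2c1` gives 12400 nM, and the step of a 3.0-fold higher number from compound 2 to compound 3 (0.48 log units; beyond the scatter) is beyond the scatter. Compound 4 `COC(=O)c1cc(Br)ccc1OC(=O)COc1cc(O)c2c(=O)cc(-c3ccccc3)oc2c1` differs from compound 3 by a group of 11 heavy atoms (8 carbon, 2 oxygen, 1 bromine; one six-membered aromatic ring of carbon only) in place of a group of 11 heavy atoms (9 carbon, 2 oxygen; one six-membered aromatic ring of carbon only), on an oxygen next to a carbonyl group. The step that bears most on it is a 2.5-fold lower number from compound 1 to compound 2 (0.40 log units; beyond the scatter), a halogen in place of a methyl group on the same phenyl ester. By that precedent a modest step to a lower number is expected for compound 4, roughly a 2.5-fold lower number from compound 3 to compound 4 (0.39 log units; beyond the scatter), though the bromine sits on a different carbon. Compound 4 is therefore estimated at 15000 nM, within a range of 6000 nM to 40000 nM.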

Compound 4, half-maximal inhibitory concentration: 780 nM
Beside the measured number, compound 4's estimate is 19-fold (1.28 log units) above it; the measured number lies below the stated range.
By their numbers in this assay, from the lowest: compound 4; then compound 2; then compounds 1 and 3 (each within the scatter of the next).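

Going by these compounds alone, on this oxygen next to a carbonyl group, the 4-bromo-2-(methoxycarbonyl)phenyl group gives much larger steps than any among the earlier compounds: a 48-fold lower number from compound 3 to compound 4 (1.68 log units; beyond the scatter), a 40-fold lower number from compound 1 to compound 4 (1.60 log units; beyond the scatter) and a 16-fold lower number from compound 2 to compound 4 (1.20 log units; beyond the scatter). The aryl group on this ester can therefore move the number far more than the exchange of chloro for methyl showed, and compound 4 also stands well clear of chloro-bearing compound 2. No evidence at hand accounts for this step. The compounds shown leave open whether the bromine itself or the carbon carrying it matters more, which a chloro in the place of the bromine of compound 4 would help separate. As far as these compounds go, whether an amine or a carboxylic acid there would keep the low number also stays open.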